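The source may report more compounds than this note shows. Statements on the series, on what has been measured and on what is new or still open speak of the compounds shown alone.

Measured compounds:
compound 1, `CC(C)(C)Cc1c(-c2ccoc2)sc(N)c1C(=O)c1ccc(Cl)cc1`, 1%
compound 2, `CC(C)(C)Cc1c(-c2ccc(F)cc2)sc(N)c1C(=O)c1ccc(Cl)cc1`, 1%
compound 3, `COc1ccccc1-c1sc(N)c(C(=O)c2ccc(Cl)cc2)c1CC(C)(C)C`, 1%

All three were tested in an assay on CHO cells for displacement of a labelled ligand from adenosine receptor A1 (Homo sapiens), read by scintillation counting, tested at 10 uM; a higher number here means more inhibition at the concentration tested (going by the name of the read-out), a lower number less inhibition. In this assay compound 3 gives 1% and stands level with compound 1 and compound 2 at the digits shown. The three measured steps all swap the aromatic group on the ring carbon next to the ring sulfur: no change at the digits printed from compound 1 to compound 2 (within the scatter), no change at the digits printed from compound 1 to compound 3 (within the scatter) and no change at the digits printed from compound 2 to compound 3 (within the scatter). Every one of them lies within the scatter.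

Compound 4, `CC(C)(C)Cc1c(-c2ccco2)sc(N)c1C(=O)c1ccc(Cl)cc1`, is not yet measured. It differs from compound 3 at the same place: furan-2-yl in place of 2-methoxyphenyl on an aromatic carbon. Within the data shown here, the steps that bear on this change are exactly those three swaps of the aromatic group, and none of them moved the read-out beyond the scatter. On the strength of no change at the digits printed from compound 1 to compound 3 (within the scatter) and no change at the digits printed from compound 2 to compound 3 (within the scatter), the expected step is no change at the digits printed from compound 3 to compound 4 (within the scatter), that is, nothing beyond the scatter in either direction. Compound 4 is therefore estimated at 1%, with a range from 0% to 10%.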

Compound 4, a percentage reported as inhibition, at one concentration (the size of the read-out at that concentration, not a potency): 1%
Estimate against measurement, compound 4: no gap at the digits printed, within the range that was stated.
By their numbers in this assay, from the lowest: compounds 1, 2, 3 and 4 (each within the scatter of the next).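

In this assay, furan-2-yl in place of the larger 2-methoxyphenyl, with its six-membered ring of carbon only, gives no change at the digits printed from compound 3 to compound 4 (within the scatter). Furan-2-yl in place of 4-fluorophenyl gives no change at the digits printed from compound 2 to compound 4 (within the scatter), so this five-membered ring reads the same as both six-membered aromatic groups at this place. Furan-2-yl in place of furan-3-yl, the first step here between two furan groups, gives no change at the digits printed from compound 1 to compound 4 (within the scatter), so the two furans cannot be told apart in this assay.

Going by these compounds, whether a group of another kind on this carbon, such as an amine or a carboxylic acid, would move the read-out stays open, as does any change to the neopentyl, amino or (4-chlorophenyl)carbonyl groups that all four compounds share. No evidence is available on what lies behind these flat results.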